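Methyl in place of chloro in compound 1

The compounds below may be only part of what the source reports. "The series", "measured", "known", "first", "only" and "open" are said of these compounds alone.

Among the compounds with values here, in an ADME assay (liver) for metabolic stability, with Liver microsome (Rattus norvegicus) as the target, read by LC-MS, using microsomes and NADPH, with stated times of 5 min and 60 min, tested at 4 uM (on this read-out higher numbers stand for a more stable compound and lower numbers for a less stable compound), compound 1 (`Cc1c(OCCCCOc2ccc(C(=O)O)cc2Cl)ccc(C(=O)CC2CCCC2)c1O`) gives 21% and so holds the lower of the two numbers measured so far. Within the data shown here, the only other measured compound is compound 2 (`Cc1c(OCCCCOc2ccc(C(=O)O)cc2Cl)ccc(C(=O)CC(C)C)c1O`), which gives 61% and carries isopropyl in place of cyclopentyl on a saturated chain carbon bound to a carbonyl carbon. That single step is a number 40 percentage points higher from compound 1 to compound 2 (beyond the scatter) and it lies at a different place from the change now in question.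

Compound 3 (`Cc1cc(C(=O)O)ccc1OCCCCOc1ccc(C(=O)CC2CCCC2)c(O)c1C`) keeps the cyclopentyl group and differs from compound 1 by methyl in place of chloro on an aromatic carbon (in short, methyl in place of chloro on an aromatic carbon). Among the measured compounds shown here, no measured step touches this place, so the large step to compound 2 gives no direct guide to size or direction. No step beyond the scatter is therefore expected in this assay in either direction, and the expectation stays close to compound 1 at 21% for want of other evidence. The expected outcome is a number 1 percentage points higher from compound 1 to compound 3 (within the scatter) as an estimate with wide uncertainty. The estimate for compound 3 is 22% with an expected range of 9% to 40%.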

Compound 3, percent of the compound remaining: 59%
Compound 3: middle estimate off by 37 percentage points, on the low side; measured number outside the range, above it.
By their numbers in this assay, from the lowest: compound 1; then compounds 3 and 2 (each within the scatter of the next).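

In this assay, exchanging chloro for methyl on this aromatic carbon, ortho to a large group and meta to a carboxy group, gives a number 38 percentage points higher from compound 1 to compound 3 (beyond the scatter) and so shows that this position matters for the read-out. Within the data shown here, until now the only step available lay at another place, the saturated chain carbon bound to a carbonyl carbon, where isopropyl in place of cyclopentyl gives a number 40 percentage points higher from compound 1 to compound 2 (beyond the scatter); a second place in the core of compound 1 now also produces a large step, and here one heavy atom replaces one heavy atom, with no change in the counted hydrogen-bond donors, hydrogen-bond acceptors or net charge. Nothing at hand accounts for the size of this step or shows what happens to the compounds in the microsomes.

Going by these compounds, it remains open whether the isopropyl and methyl changes would add up if both stood in one compound, or whether one would make the other redundant. On these data alone, it is also open whether the step belongs to methyl itself or to the loss of chloro, which a hydrogen, fluoro, methoxy or ethyl group at this aromatic carbon could help to separate.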